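One group exchanged on a chloro compound

This account rests on a few compounds, and the source may have more. Where it says the series, first, only, none or still open, it means among the compounds named here.

In a functional assay on NCI-H322M cells (Homo sapiens) for inhibition (on this read-out lower numbers stand for stronger inhibition of growth and higher numbers for weaker inhibition of growth), compound 1 (`COc1cc(/C=C/C(=O)c2cccc(-n3cc(-c4ccccc4)[nH]c3=O)c2)ccc1O`) gives 3390 nM, compound 2 (`O=C(/C=C/c1cccc(O)c1)c1cccc(-n2cc(-c3ccccc3)[nH]c2=O)c1`) gives 10600 nM and compound 3 (`O=C(/C=C/c1cccc(O)c1)c1cccc(-n2cc(-c3ccc(Cl)cc3)[nH]c2=O)c1`) gives 2520 nM. Compound 3 thus sits within the scatter of compound 1 and clearly apart from compound 2. Compound 4 (`COc1cc(/C=C/C(=O)c2cccc(-n3cc(-c4ccc(Cl)cc4)[nH]c3=O)c2)ccc1O`), not yet measured, carries 4-hydroxy-3-methoxyphenyl in place of 3-hydroxyphenyl on a double-bonded chain carbon bound to a double-bonded chain carbon. The reverse exchange gave a 3.1-fold higher number from compound 1 to compound 2 (0.50 log units; beyond the scatter), and chloro in place of hydrogen on an aromatic carbon gave a 4.2-fold lower number from compound 2 to compound 3 (0.62 log units; beyond the scatter). From the compounds shown here alone, whether these two modest steps add up is untested, so a somewhat smaller step is expected here. The expected change is a 2.3-fold lower number from compound 3 to compound 4 (0.36 log units; beyond the scatter). The estimate for compound 4 is 1100 nM, with an expected range of 400 nM to 2800 nM.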

Compound 4, concentration for 50% growth inhibition: 4580 nM
Beside the measured number, compound 4's estimate is 4.2-fold (0.62 log units) below it, and the stated range ends below it.
By their numbers in this assay, from the lowest: compounds 3, 1 and 4 (each within the scatter of the next); then compound 2.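

With the chloro group present, 4-hydroxy-3-methoxyphenyl in place of 3-hydroxyphenyl gives a 1.8-fold higher number from compound 3 to compound 4 (0.26 log units; within the scatter), so this exchange does not repeat the clear step seen without chloro: the same change on two cores in this assay, a 3.1-fold higher number (0.50 log units; beyond the scatter) from compound 1 to compound 2 and a 1.8-fold lower number (0.26 log units; within the scatter) from compound 4 to compound 3, 5.7-fold (0.75 log units) apart, beyond the scatter of two such steps. Likewise, on the 4-hydroxy-3-methoxyphenyl core, chloro in place of hydrogen gives a 1.4-fold higher number from compound 1 to compound 4 (0.13 log units; within the scatter), unlike its clear step on the 3-hydroxyphenyl core: the same change on two cores in this assay, a 4.2-fold lower number (0.62 log units; beyond the scatter) from compound 2 to compound 3 and a 1.4-fold higher number (0.13 log units; within the scatter) from compound 1 to compound 4, 5.7-fold (0.75 log units) apart, beyond the scatter of two such steps. The two exchanges therefore do not add up in these four compounds, and the size of each depends on the other.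

From the compounds shown here alone, it remains open whether a bromo or a methyl in place of the chloro, or an amine in place of the hydroxy group, would show the same dependence. These compounds also do not tell why the two exchanges depend on each other.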